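The source may report more compounds than this note shows. Statements on the series, on what has been measured and on what is new or still open speak of the compounds shown alone.

Measured compounds:
- compound 1, `COC(=O)c1cccc(-c2cnc3[nH]cc(-c4cncnc4)c3c2)c1`: 62.5 nM
- compound 2, `COC(=O)c1cccc(-c2cnc3[nH]cc(-c4cccnc4)c3c2)c1`: 11.5 nM
- compound 3, `COC(=O)c1cccc(-c2cnc3[nH]cc(-c4cccc(OC)c4)c3c2)c1`: 166 nM

In an assay on isolated protein for inhibition of serine/threonine-protein kinase Nek1 (Homo sapiens), read by radiometric assay and 33P incorporation, in the presence of a further agent that is not named here (on this read-out higher numbers stand for weaker inhibition and lower numbers for stronger inhibition), compound 3 gives the highest number of the three. Its nearest neighbour is compound 1, with a 2.7-fold higher number from compound 1 to compound 3 (0.42 log units; beyond the scatter); the gap to compound 2 is larger, as a 14-fold higher number from compound 2 to compound 3 (1.16 log units; beyond the scatter) shows. Both steps lie beyond the scatter, so compound 3 is the weakest of the measured set.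

Compound 4, `COC(=O)c1cccc(-c2cnc3[nH]cc(-c4ccncc4)c3c2)c1`, is not yet measured. It differs from compound 3 in one place: pyridin-4-yl in place of 3-methoxyphenyl on an aromatic carbon; the place is on an aromatic carbon of a five-membered aromatic ring with one nitrogen, part of a fused or bridged system of two rings, two ring bonds from the ring nitrogen.

For the measured compounds named here, two measured steps bear on this change, both replacing a six-membered carbon-only ring at that position with a ring carrying nitrogen. The step of a 2.7-fold higher number from compound 1 to compound 3 (0.42 log units; beyond the scatter) was modest, the step of a 14-fold higher number from compound 2 to compound 3 (1.16 log units; beyond the scatter) large, and both run in the same direction, towards weaker inhibition on the carbon-only ring. Compound 4 carries a nitrogen-containing ring again, so in this assay a lower number than compound 3 is expected, by a step estimated as a 5.5-fold lower number from compound 3 to compound 4 (0.74 log units; beyond the scatter). The estimate for compound 4 is 30 nM, with a range from 8 nM to 120 nM.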

Compound 4, half-maximal inhibitory concentration: 140 nM
Compound 4: the middle estimate sits 4.7-fold (0.67 log units) below what was measured; measured number outside the range, above it.
By their numbers in this assay, from the lowest: compound 2; then compound 1; then compounds 4 and 3 (each within the scatter of the next).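

In this assay, a ring nitrogen at this position does not by itself bring a lower number: pyridin-4-yl in place of 3-methoxyphenyl leaves the two compounds within the scatter of each other (a 1.2-fold lower number from compound 3 to compound 4 (0.07 log units; within the scatter)), so compound 4 goes against the trend that compound 1 and compound 2 suggested. The nitrogen-bearing rings do not behave as one group, as pyridin-4-yl in place of pyridin-3-yl gives a large step (a 12-fold higher number from compound 2 to compound 4 (1.09 log units; beyond the scatter)), while pyridin-4-yl in place of pyrimidin-5-yl gives a modest one (a 2.2-fold higher number from compound 1 to compound 4 (0.35 log units; beyond the scatter)). No measurement shown here explains why these closely related rings differ.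

The compounds shown leave open whether a plain phenyl ring would read like 3-methoxyphenyl, and whether the large gap between pyridin-3-yl and pyridin-4-yl would persist with an amine or a methoxy group on the pyridine ring. They also leave open whether the same order of these rings would hold if a carboxylic acid or an amide replaced the methyl ester shared by all four compounds.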